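The source may hold more compounds than are shown below. What is called first, only, known or untested is meant among the compounds shown, and "the series" means these compounds.

Measured in a functional assay on PC-3 cells (Homo sapiens) for inhibition, read by MTT assay, with a stated time of 48 h; on this read-out higher numbers stand for weaker inhibition and lower numbers for stronger inhibition:
compound 1 `COc1ccc(CN(c2cc(OC)c(OC)c(OC)c2)S(=O)(=O)c2ccc(C)cc2)cc1` gives 8220 nM;
compound 2 `COc1cc(N(Cc2nc3ccccc3[nH]2)S(=O)(=O)c2ccc(C(C)(C)C)cc2)cc(OC)c1OC` gives 29800 nM;
compound 3 `Cc1ccc(S(=O)(=O)N(Cc2nc3ccccc3[nH]2)c2ccc(Cl)cc2)cc1` gives 42200 nM.

Among these three numbers compound 3 has the highest. The number for compound 2 lies within the scatter of it, so no order between those two can be claimed, while compound 1 sits at a lower number beyond the scatter.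

Compound 4 `COc1ccc(N(Cc2nc3ccccc3[nH]2)S(=O)(=O)c2ccc(C)cc2)cc1OC` differs from compound 3 by 3,4-dimethoxyphenyl in place of 4-chlorophenyl on a sulfonamide nitrogen. Among the measured compounds shown here, no measured pair shows this exact change, so the expectation rests on neighbours. A small step towards a lower number, or none beyond the scatter, is expected in this assay, because compound 2, which shares the benzimidazolylmethyl group and carries methoxy groups on its ring, gives 29800 nM. The expected step is a 2.1-fold lower number from compound 3 to compound 4 (0.32 log units; beyond the scatter). Compound 4 is thus estimated at 20000 nM, within 6000 nM to 60000 nM.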

Compound 4, half-maximal inhibitory concentration: > 50000 nM
Compound 4: only a limit was reported (the forecaster's own chance of this, stated with the estimate: 10%); middle value at least 2.5-fold (0.39 log units) from the limit.
By their numbers in this assay, from the lowest: compound 1; then compounds 2 and 3 (each within the scatter of the next). At a limit, above all of these: compound 4.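

Among the compounds shown here, compound 4 is the first case here in which only the ring on the sulfonamide nitrogen changes, and 3,4-dimethoxyphenyl in place of 4-chlorophenyl brings no drop in the number: the step is an at least 1.1-fold higher number from compound 3 to compound 4 (0.07 log units; that floor lies within the scatter). Compound 4 is reported only as a limit, > 50000 nM. The true size of the step therefore stays unknown, and its floor alone does not establish weaker inhibition: the limit of > 50000 nM in this assay, at which 1 of the 4 values shown sits.

As far as these compounds go, whether an amine or a carboxylic acid on this ring would give a lower number stays open. So does the outcome of a plain butyl chain in place of the ring.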